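This account rests on a few compounds, and the source may have more. Where it says the series, first, only, none or still open, it means among the compounds named here.

Working notes on the series. In a functional assay on MIA PaCa-2 cells (Homo sapiens) for cytotoxicity, read by MTT assay, with a stated time of 24 h (on this read-out higher numbers stand for weaker inhibition and lower numbers for stronger inhibition), compound 1 (`CC[C@H](C)[C@@H](O)C(=O)O[C@@H](C(=O)O[C@@H](C(=O)O[C@@H](C(=O)O[C@@H](C(=O)OC[C@@H](O)[C@@H](O)[C@H](O)CO)[C@@H](C)CC)[C@@H](C)CC)[C@@H](C)CC)[C@@H](C)CC`) gives > 55400 nM, which is a limit and not a number. Compound 2 (`CC[C@H](C)[C@@H](O)C(=O)O[C@@H](C(=O)O[C@@H](C(=O)O[C@@H](C(=O)O[C@@H](C(=O)OC[C@@H](O)[C@@H](O)[C@H](O)[C@H](O)CO)[C@@H](C)CC)[C@@H](C)CC)[C@@H](C)CC)[C@@H](C)CC`) gives > 53200 nM in this assay, which is also a limit. Going by the values given here, compound 1 therefore has no measured number to stand on, and neither value so far is more than a limit.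

Compound 3 (`CC[C@H](C)[C@@H](O)C(=O)O[C@@H](C(=O)O[C@@H](C(=O)O[C@@H](C(=O)OC[C@@H](O)[C@@H](O)[C@H](O)CO)[C@@H](C)CC)[C@@H](C)CC)[C@@H](C)CC`) is the next to be read. The change is hydrogen in place of (1-hydroxy-2-methylbutyl)carbonyl on an oxygen on a saturated carbon.

Among the compounds with values here, only one measured step exists, a step that the two limits leave unreadable from compound 1 to compound 2. It concerns a different change, a hydroxymethyl in place of hydrogen, and it has no readable size. It therefore offers no size or direction to carry over. Within the data shown here, since compound 2 shows only the step that the two limits leave unreadable from compound 1 to compound 2, no shift beyond the scatter is expected for the new change, and a further limit is the likely report. The expected step, a step that the limit leaves unreadable from compound 1 to compound 3, is accordingly small and without a firm direction. Compound 3 is estimated at 65000 nM, with an expected range of 40000 nM to 80000 nM.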

Compound 3, half-maximal inhibitory concentration: > 65700 nM
Compound 3: no number, only a limit; the forecaster's own chance of this, stated with the estimate: 85%; at least 1.0-fold (0.00 log units) between middle value and limit.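

In this assay compound 3 gives > 65700 nM, which is a limit and not a number. Compound 1 also stands only at a limit, so no step can be read between compound 1 and compound 3. The compounds shown leave open what size or direction either change has, and whether compound 1, compound 2 or compound 3 has a measurable value in this assay.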